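Swapping methylpiperazine for piperidine on two related cores

A few compounds are considered here, and "the series" means these few. Any claim that something is new, unique, unknown or untested is made for them only; others in the source may bear on it.

compound 1 `CN1CCN(c2ccc(Nc3ncc4c(n3)N(C3CCCC3)CC(=O)N4)nc2)CC1`: > 30000 nM
compound 2 `O=C1CN(C2CCCC2)c2nc(Nc3ccc(N4CCCCC4)cn3)ncc2N1`: > 30000 nM
compound 3 `CN1CCN(c2ccc(Nc3ncc4c(n3)N(C3CCCC3)CC(=O)N4C)cc2)CC1`: 10300 nM

In a functional assay on MDA-MB-231 cells (Homo sapiens) for inhibition, read by MTT assay, with a stated time of 48 h (on this read-out higher numbers stand for weaker inhibition and lower numbers for stronger inhibition), compound 1 gives > 30000 nM, which is a limit of the assay and not a number. Compound 2 gives > 30000 nM, again a limit. Compound 2 differs from compound 1 by piperidin-1-yl in place of 4-methylpiperazin-1-yl on an aromatic carbon, and the step that the two limits leave unreadable from compound 1 to compound 2 cannot be read because of the limit of > 30000 nM in this assay, at which 2 of the 3 values shown sit. Among the compounds with values here, compound 3 gives 10300 nM, the only number here. The difference between the core of compound 3 and the core of compound 1 is not broken down here. Compound 4 `CN1C(=O)CN(C2CCCC2)c2nc(Nc3ccc(N4CCCCC4)cc3)ncc21` is not yet measured; it differs from compound 3 by piperidin-1-yl in place of 4-methylpiperazin-1-yl on an aromatic carbon, the same kind of change as before, though here the place is a six-membered aromatic ring of carbon only rather than a ring with 1 nitrogen, two atoms from the ring nitrogen. With the earlier step unreadable, the step of a 1.5-fold higher number from compound 3 to compound 4 (0.16 log units; within the scatter) is expected to be modest, resting on compound 3 and its 10300 nM alone. Compound 4 is therefore estimated at 15000 nM, expected between 5000 nM and 40000 nM.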

Compound 4, half-maximal inhibitory concentration: 21200 nM
Compound 4: the middle estimate sits 1.4-fold (0.15 log units) below what was measured; measured number inside the range.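

In this assay, putting piperidin-1-yl in place of 4-methylpiperazin-1-yl on the core of compound 3 gives a 2.1-fold higher number from compound 3 to compound 4 (0.31 log units; beyond the scatter), a modest weakening on this one core. Whether the same change does the same on the core of compound 1 cannot be said, because the step from compound 1 to compound 2 cannot be read: the limit of > 30000 nM in this assay, at which 2 of the 4 values shown sit. The result therefore gives the size of the change on a single core and does not show that it carries over to another.

The compounds shown leave open how a morpholin-4-yl group or a dimethylamino group on the same aromatic carbon would compare. They also leave open which of the differences between the two cores matters in this assay.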